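A nitro group added to compound 3

A few compounds are considered here, and "the series" means these few. Any claim that something is new, unique, unknown or untested is made for them only; others in the source may bear on it.

Measured in a functional assay on QGY-7703 cells (Homo sapiens) for cytotoxicity, read by MTT assay, with a stated time of 24 h (a lower number here means a stronger inhibitor, a higher number a weaker inhibitor), so far
Compound 1 `COc1cc(/C=C2\CN(C)C/C(=C\c3cccnc3)C2=O)cc(OC)c1` gives 7900 nM
Compound 2 `COc1ccc(/C=C2\CN(C)C/C(=C\c3cccnc3)C2=O)c(OC)c1OC` gives 2630 nM
Compound 3 `CN1C/C(=C\c2cccnc2)C(=O)/C(=C/c2ccccc2F)C1` gives 4470 nM

Compound 3, at 4470 nM in this assay, lies within the scatter of both compound 2 and compound 1, so its place among the three is not firm. The next compound to be tested is compound 4 `CN1C/C(=C\c2cccnc2)C(=O)/C(=C/c2cc([N+](=O)[O-])ccc2F)C1`, which carries nitro in place of hydrogen on an aromatic carbon of compound 3. The new group stands para to a fluoro group and meta to a large group. Within the data shown here, no two measured compounds differ in one place only, and none of them carries a nitro group, so no measured step speaks for this change. Among the measured compounds shown here, the only guide is the spread of values, with compound 2 at 2630 nM and compound 1 at 7900 nM in the same series. A step no larger than the scatter is therefore expected in this assay, leaning slightly toward a lower number. The estimate means a 1.5-fold lower number from compound 3 to compound 4 (0.17 log units; within the scatter) as the expected change. For compound 4 the estimated value is 3000 nM, with a range from 1000 nM to 9000 nM expected.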

Compound 4, half-maximal inhibitory concentration: 11100 nM
Estimate against measurement, compound 4: 3.7-fold (0.57 log units) below; the whole stated range lies below it.
By their numbers in this assay, from the lowest: compounds 2, 3, 1 and 4 (each within the scatter of the next, the first and the last beyond it).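

In this assay, among these compounds, the change from hydrogen to nitro gives the first step that can be read at a single place: a 2.5-fold higher number from compound 3 to compound 4 (0.40 log units; beyond the scatter) is a modest weakening, and it lies beyond the scatter. The earlier compounds shown here, which differ in more than one place, could not show that this aromatic carbon, para to a fluoro group and meta to a large group, is sensitive to substitution, and here a nitro group makes the compound a weaker inhibitor rather than a stronger one. No measurement shown here explains why the number rises.

From the compounds shown here alone, it remains open whether the rise is specific to nitro or would also follow from another group on the same carbon, such as an amine or a nitrile. Going by these compounds, it is equally open whether nitro would have the same effect on a ring without the fluoro group.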